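Chlorophenyl amides: a change of chloro position

This account rests on a few compounds, and the source may have more. Where it says the series, first, only, none or still open, it means among the compounds named here.

In a functional assay on NCI-H460 cells (Homo sapiens) for inhibition, read by MTT assay, with a stated time of 24 h, tested at 10 ug/mL (a lower number here means less inhibition of growth, a higher number more inhibition of growth at the concentration tested), compound 1 (`CC(=O)SCCC(CCCCC(=O)O)SC(C)=O`) gives 6.04%, compound 2 (`CC(=O)SCCC(CCCCC(=O)Nc1ccccc1)SC(C)=O`) gives 14.2% and compound 3 (`CC(=O)SCCC(CCCCC(=O)Nc1ccccc1Cl)SC(C)=O`) gives 11.4%. Compound 3 therefore stands within the scatter of both other compounds. Compound 4 (`CC(=O)SCCC(CCCCC(=O)Nc1cccc(Cl)c1)SC(C)=O`) differs from it as follows: 3-chlorophenyl in place of 2-chlorophenyl on an amide-type nitrogen. In short, 3-chlorophenyl stands in place of 2-chlorophenyl on an amide-type nitrogen.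

For the measured compounds named here, no measured step covers this exact change. The closest is the chloro addition, a number 2.8 percentage points lower from compound 2 to compound 3 (within the scatter). Replacing hydroxy gave a number 8.2 percentage points higher from compound 1 to compound 2 (within the scatter) and a number 5.4 percentage points higher from compound 1 to compound 3 (within the scatter). With all three so small, no step beyond the scatter is expected in this assay. The expected step is a number 0.6 percentage points higher from compound 3 to compound 4 (within the scatter). For compound 4 the estimated value is 12%, with an expected range of 4% to 22%.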

Compound 4, percent growth inhibition at one concentration: 2.09%
Estimate against measurement, compound 4: 9.9 percentage points above, outside the stated range (below it).
By their numbers in this assay, from the lowest: compounds 4, 1, 3 and 2 (each within the scatter of the next, the first and the last beyond it).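

In this assay, 3-chlorophenyl in place of 2-chlorophenyl on the amide-type nitrogen gives a number 9.3 percentage points lower from compound 3 to compound 4 (within the scatter), and (3-chlorophenyl)amino in place of hydroxy gives a number 4 percentage points lower from compound 1 to compound 4 (within the scatter). Chloro in place of hydrogen on an aromatic carbon, however, now gives a number 12.1 percentage points lower from compound 2 to compound 4 (beyond the scatter), whereas the same addition in 2-chlorophenyl stayed within the scatter, so the outcome of chloro addition differs between these two placements. No measurement bears on why this is so.

Open, as far as these compounds go, is whether benzyl or methoxyphenyl on the amide-type nitrogen would depart from compound 2 as compound 4 does. From the compounds shown here alone, a longer chain in the shared core also remains open.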